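Turning One Ring Carbon in Compound 1

The source may hold more compounds than are shown below. What is called first, only, known or untested is meant among the compounds shown, and "the series" means these compounds.

Among the compounds with values here, compound 1 `C=C1CCC[C@H]2[C@](C)(CC[C@]3(C)CC[C@H]([C@@H](C)C(=O)O)OO3)[C@@H](C)CC[C@]12C` is the one compound here with a number: in a functional assay on SK-OV-3 cells (Homo sapiens) for inhibition (on this read-out lower numbers stand for stronger inhibition of growth and higher numbers for weaker inhibition of growth), compound 1 gives 1570 nM. Compound 2 `CC1=C(CC/C(C)=C/CC[C@@]2(C)CC[C@H]([C@H](C)C(=O)O)OO2)C(C)(C)CCC1` sits at a limit of this assay, where compound 2 gives > 5000 nM. That value is a limit, not a number (the limit of > 5000 nM in this assay, at which 1 of the 2 values shown sits). Within the data shown here, compound 3 `C=C1CCC[C@H]2[C@](C)(CC[C@]3(C)CC[C@@H]([C@@H](C)C(=O)O)OO3)[C@@H](C)CC[C@]12C` is not yet measured. the two compounds have the same atoms and bonds and differ only in configuration as drawn: 1 of 7 stereo elements differ; a stereocentre at a saturated ring carbon is drawn R in compound 1 and S in compound 3 No measured step between two compounds that differ only in configuration is available, so the direction is open; a moderate step either way is as plausible as none beyond the scatter. Compound 3 is expected to give about 3000 nM, between 800 nM and 8000 nM, an estimated step of a 1.9-fold higher number from compound 1 to compound 3 (0.28 log units; within the scatter).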

Compound 3, concentration for 50% growth inhibition: 970 nM
Compound 3: middle estimate off by 3.1-fold (0.49 log units), on the high side; measured number inside the range.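

In this assay, redrawing the stereocentre at a saturated ring carbon from R to S comes with a 1.6-fold lower number from compound 1 to compound 3 (0.21 log units; within the scatter). Within the data shown here, this is the first readable step here, and on this read-out the configuration at this carbon does not separate the two compounds. The step can be tied to this one centre alone: the fact that compounds 1 and 3 differ only in the configuration as drawn

The compounds shown leave open whether the other stereo elements matter as little. They also leave open how the core of compound 3 would behave with a methyl ester or an amide in place of the carboxylic acid.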